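Amide aryl exchange in a bis(trifluoromethyl)benzoyl piperidine series

The compounds below may be only part of what the source reports. "The series", "measured", "known", "first", "only" and "open" are said of these compounds alone.

Compound 3 `Cn1cnnc1-c1cccc(NC(=O)C2CCCN(C(=O)c3cc(C(F)(F)F)cc(C(F)(F)F)c3)C2)c1` is the reference point for this step. In an ADME assay on PC-3 cells (Homo sapiens) for cytotoxicity, read by WST assay, tested at 100 uM (on this read-out higher numbers stand for more inhibition at the one concentration tested (going by the name of the read-out) and lower numbers for less inhibition), compound 3 gives 0%. The two neighbours on the same core sit at the same level: in this assay compound 1 `O=C(Nc1cccc(N2CCCC2=O)c1)C1CCCN(C(=O)c2cc(C(F)(F)F)cc(C(F)(F)F)c2)C1` gives 0%, and compound 2 `CCc1cccc(NC(=O)C2CCCN(C(=O)c3cc(C(F)(F)F)cc(C(F)(F)F)c3)C2)c1` gives 0%. Compound 3 is thus level with both, the steps of no change at the digits printed from compound 1 to compound 3 (within the scatter) and no change at the digits printed from compound 2 to compound 3 (within the scatter) showing no movement, as does no change at the digits printed from compound 1 to compound 2 (within the scatter).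

Compound 4 `O=C(Nc1ccc(Cl)cn1)C1CCCN(C(=O)c2cc(C(F)(F)F)cc(C(F)(F)F)c2)C1` is not yet measured. It differs from compound 3 by 5-chloropyridin-2-yl in place of 3-(4-methyl-4H-1,2,4-triazol-3-yl)phenyl on an amide-type nitrogen. Within the data shown here, none of the measured steps bears on this change directly: each of them exchanges a single group on the aromatic ring, whereas the step to compound 4 replaces the whole aromatic unit attached to the amide-type nitrogen. What the measured set does show is that three different groups on that ring all leave the read-out at the same level, with no step beyond the scatter. Absent any measured step that moved the read-out, the expectation for compound 4 is no movement beyond the scatter, so that no change at the digits printed from compound 3 to compound 4 (within the scatter) is expected to be flat. The estimate for compound 4 in this assay is 0%, with an expected range from -5% to 10%.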

Compound 4, a percentage reported as inhibition, at one concentration (the size of the read-out at that concentration, not a potency): 0%
Beside the measured number, compound 4's estimate shows no gap at the digits printed, within the range that was stated.
By their numbers in this assay, from the lowest: compounds 1, 2, 3 and 4 (each within the scatter of the next).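

In this assay, swapping the whole aromatic unit on the amide-type nitrogen gives no change at the digits printed from compound 3 to compound 4 (within the scatter), no change at the digits printed from compound 2 to compound 4 (within the scatter) and no change at the digits printed from compound 1 to compound 4 (within the scatter). Among these compounds, the earlier compounds varied only a single group on the phenyl ring, whereas here the flat read-out also holds when that phenyl unit, with 3-(4-methyl-4H-1,2,4-triazol-3-yl), 3-ethyl or 3-(2-oxopyrrolidin-1-yl) on it, gives way to 5-chloropyridin-2-yl, a unit with a ring nitrogen and a chlorine. No supporting information is available to account for this flat result.

Since no step among these four compounds lies beyond the scatter, it remains open whether any group on the amide-type nitrogen can move this read-out at the one concentration tested. On these data alone, the effect of a carboxylic acid or a primary amine on the aromatic unit, of a plain alkyl chain in place of that unit on the amide-type nitrogen, or of a change elsewhere on the shared core, also stays open.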